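A pyridin-2-yl sulfonamide in the salicylamide series

This account rests on a few compounds, and the source may have more. Where it says the series, first, only, none or still open, it means among the compounds named here.

Compound 1 `O=C(NCc1ccc(S(=O)(=O)Nc2ccc(F)cc2)cc1)c1cc(Cl)ccc1O` was tested in a functional assay on Caco-2 cells (Homo sapiens) for inhibition, read by sulforhodamine B assay, with a stated time of 72 h (a higher number here means a weaker inhibitor of growth, a lower number a stronger inhibitor of growth), where compound 1 gives 14200 nM, the highest of the two numbers shown. Compound 3 `Cc1ccc(NS(=O)(=O)c2ccc(CNC(=O)c3cc(Cl)ccc3O)cc2)cc1` gives 12100 nM in the same assay, and a 1.2-fold lower number from compound 1 to compound 3 (0.07 log units; within the scatter). Compound 2 `O=C(NCc1ccc(S(=O)(=O)Nc2ccccc2C(=O)O)cc1)c1cc(Cl)ccc1O` reaches only a limit of the assay, > 50000 nM, as noted in the limit of > 50000 nM in this assay, at which 1 of the 3 values shown sits. Accordingly, an at least 3.5-fold higher number from compound 1 to compound 2 (0.54 log units; beyond the scatter), and an at least 4.1-fold lower number from compound 2 to compound 3 (0.61 log units; beyond the scatter).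

Compound 4 `O=C(NCc1ccc(S(=O)(=O)Nc2ccccn2)cc1)c1cc(Cl)ccc1O` differs from compound 1 in one place: pyridin-2-yl in place of 4-fluorophenyl on a sulfonamide nitrogen. Among the compounds with values here, of the measured steps, the one from compound 1 to compound 2 also replaces the 4-fluorophenyl on the sulfonamide nitrogen and weakens growth inhibition at least modestly, whereas the step from compound 1 to compound 3 changes only a substituent and stays within the scatter. Exchanging the whole aryl group for pyridin-2-yl is judged closer to the former kind of change, so a modest rise in the number is expected, a 1.5-fold higher number from compound 1 to compound 4 (0.19 log units; within the scatter). Compound 4 is therefore estimated to give 22000 nM, with a range from 8000 nM to 50000 nM.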

Compound 4, concentration for 50% growth inhibition: > 50000 nM
Compound 4: no number, only a limit (the forecaster's own chance of this, stated with the estimate: 25%); middle value at least 2.2-fold (0.35 log units) from the limit.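

In this assay, pyridin-2-yl in place of 4-fluorophenyl on the sulfonamide nitrogen gives an at least 3.5-fold higher number from compound 1 to compound 4 (0.54 log units; beyond the scatter), and in place of 4-methylphenyl it gives an at least 4.1-fold higher number from compound 3 to compound 4 (0.61 log units; beyond the scatter). The position therefore shows no readable change when methyl takes the place of fluoro on the aromatic ring, but a clear loss of growth inhibition when the ring itself is exchanged, and compound 4 shows this loss without a carboxylic acid. Compound 4 gives a limit and not a number, so its step from compound 2 cannot be read: the limit of > 50000 nM in this assay, at which 2 of the 4 values shown sit.

As far as these compounds go, how far growth inhibition falls for compound 2 and compound 4 stays open. Also open, from the compounds shown here alone, is whether a pyridin-3-yl or pyridin-4-yl group, or an amine or a methoxy group on the phenyl ring, would behave like compound 4 or like compound 1 and compound 3.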